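Swapping 4-aminophenyl for furan-2-yl on the shared core

The compounds below may be only part of what the source reports. "The series", "measured", "known", "first", "only" and "open" are said of these compounds alone.

Compound 1 `COc1ccc(S(=O)(=O)N2CCc3cccc(-c4ccc(N)cc4)c32)cc1` gives 249 nM here
Compound 2 `COc1ccc(S(=O)(=O)N2CCc3cccc(-c4ccc(F)nc4)c32)cc1` gives 143 nM here

In a functional assay on KB cells (Homo sapiens) for inhibition, with a stated time of 72 h (a higher number here means a weaker inhibitor, a lower number a stronger inhibitor), compound 1 gives 249 nM and lies within the usual scatter of compound 2. Compound 3 `COc1ccc(S(=O)(=O)N2CCc3cccc(-c4ccco4)c32)cc1` keeps the shared core but has furan-2-yl in place of 4-aminophenyl on an aromatic carbon, and furan-2-yl in place of 4-aminophenyl on an aromatic carbon sets out the full difference. Among the compounds with values here, the only measured step that bears on this is a 1.7-fold lower number from compound 1 to compound 2 (0.24 log units; within the scatter) when 6-fluoropyridin-3-yl replaces that same group. From the compounds shown here alone, one step is little to go on, and furan-2-yl itself remains untested. The expected change is a 1.4-fold lower number from compound 1 to compound 3 (0.14 log units; within the scatter) in size, nothing beyond the scatter. For compound 3 the estimate is 180 nM with an expected range of 60 nM to 500 nM in this measurement.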

Compound 3, half-maximal inhibitory concentration: 82 nM
Compound 3: middle estimate off by 2.2-fold (0.34 log units), on the high side, and the stated range covers the measured number.
By their numbers in this assay, from the lowest: compounds 3, 2 and 1 (each within the scatter of the next, the first and the last beyond it).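

In this assay, this position now shows a step beyond the scatter (a 3.0-fold lower number from compound 1 to compound 3 (0.48 log units; beyond the scatter)): a five-membered furan-2-yl ring can replace the larger 4-aminophenyl here without any loss. Against the other replacement, the values stay within the scatter (a 1.7-fold lower number from compound 2 to compound 3 (0.24 log units; within the scatter)), so furan-2-yl and 6-fluoropyridin-3-yl cannot be told apart. Nothing measured here explains the step.

From the compounds shown here alone, whether the ring size, the ring oxygen or the missing hydrogen-bond donor matters most remains open. So does how a thiophen-2-yl or a plain methyl at this aromatic carbon would compare.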